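Hydroxylated sulfur side chains: compound 3 to compound 4

This account rests on a few compounds, and the source may have more. Where it says the series, first, only, none or still open, it means among the compounds named here.

Measured so far in a physicochemical assay for solubility (a higher number here means a more soluble compound, a lower number a less soluble compound), as solubility:
- Compound 1 `CC(C)(C)Sc1c(O)nc2ccc(C(F)(F)F)cc2c1-c1cc(Cl)ccc1O` gives < 1 ug/mL (a limit)
- Compound 2 `CSc1c(O)nc2ccc(C(F)(F)F)cc2c1-c1cc(Cl)ccc1O` gives < 1 ug/mL (a limit)
- Compound 3 `OCCCSc1c(O)nc2ccc(C(F)(F)F)cc2c1-c1cc(Cl)ccc1O` gives 3 ug/mL (a number)

Compound 1 and compound 2 both stand at the limit of < 1 ug/mL in this assay, at which 2 of the 3 values shown sit, and no more can be read from them. Compound 3 alone has a true number. Compound 4 `OCC(O)CSc1c(O)nc2ccc(C(F)(F)F)cc2c1-c1cc(Cl)ccc1O` takes hydroxy in place of hydrogen on a saturated chain carbon bound to two saturated chain carbons and so turns 3-hydroxypropyl to 2,3-dihydroxypropyl. Among the compounds with values here, two measured steps bear on this, an at least 3.0-fold higher number from compound 1 to compound 3 (0.47 log units; beyond the scatter) and an at least 3.0-fold higher number from compound 2 to compound 3 (0.47 log units; beyond the scatter) and both are lower bounds that start from a limit. On those two steps to compound 3, a modest rise in this assay is expected, with the expected step of a 2.0-fold higher number from compound 3 to compound 4 (0.30 log units; within the scatter) and no fall. For compound 4 the estimated value is 6 ug/mL with an expected range of 2 ug/mL to 20 ug/mL around it.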

Compound 4, solubility: 190 ug/mL
Compound 4: middle estimate off by 32-fold (1.50 log units), on the low side; the measured number lies above the stated range.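

In this assay, the sulfur side chain still had much room at 3-hydroxypropyl: 2,3-dihydroxypropyl gives a 63-fold higher number from compound 3 to compound 4 (1.80 log units; beyond the scatter). Against the two simple alkyl side chains, the readings are an at least 190-fold higher number from compound 2 to compound 4 (2.27 log units; beyond the scatter) and an at least 190-fold higher number from compound 1 to compound 4 (2.27 log units; beyond the scatter). These two steps are lower bounds only, because each starts from a limit: the limit of < 1 ug/mL in this assay, at which 2 of the 4 values shown sit.

From the compounds shown here alone, whether the same jump would come with an amine or a carboxylic acid at this position remains open. So does whether a longer chain bearing further hydroxy groups would extend it.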